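This account rests on a few compounds, and the source may have more. Where it says the series, first, only, none or still open, it means among the compounds named here.

Measured so far:
- Compound 1, `NC(=O)c1ccc(Cn2cc(-c3ccc4cn[nH]c4c3)ccc2=O)cc1`: > 2000 nM in an assay for inhibition of MAP kinase-interacting serine/threonine-protein kinase 2 (Homo sapiens), read by luminescence and ADP-Glo, with a stated time of 2 h; on this read-out higher numbers stand for weaker inhibition and lower numbers for stronger inhibition
- Compound 2, `O=c1ccc(-c2ccc3cn[nH]c3c2)cn1Cc1cccc(C(F)(F)F)c1`: 32 nM
- Compound 3, `Cn1cc2ccc(-c3ccc(=O)n(Cc4ccccc4)c3)cc2n1`: > 2000 nM

Of the compounds shown here, three sharing one core have been tested in this assay. For compound 1 the result is only a limit of the assay, > 2000 nM. For compound 3 the result is likewise only a limit, > 2000 nM. Among the measured compounds shown here, compound 2 is thus the only compound with a real number, 32 nM. The other two readings sit at the limit; this is shown by the limit of > 2000 nM in this assay, at which 2 of the 3 values shown sit. No pair of these compounds differs in just one place, so no single measured step can be separated out.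

Compound 4, `CC(=O)Nc1cccc(Cn2cc(-c3ccc4cn[nH]c4c3)ccc2=O)c1`, has not yet been tested. It differs from compound 2 in one place: acetamido in place of trifluoromethyl on an aromatic carbon. The trifluoromethyl group that leaves is the feature compound 2 carries on its benzyl ring, and the acetamido group that enters resembles the amide found in compound 1, whose reading in this assay gave only a limit, > 2000 nM. On this basis a loss of potency beyond the usual scatter is expected for the step of a 19-fold higher number from compound 2 to compound 4 (1.27 log units; beyond the scatter). Compound 4 is therefore estimated at 600 nM, with a plausible range from 100 nM to 3000 nM, and a fair chance that only a limit is reported.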

Compound 4, half-maximal inhibitory concentration: 43 nM
Beside the measured number, compound 4's estimate is 14-fold (1.14 log units) above it; measured number below the stated range.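

Replacing trifluoromethyl with acetamido on this aromatic carbon, meta to a large group, gives a 1.3-fold higher number from compound 2 to compound 4 (0.13 log units; within the scatter) in this assay, so this position holds either group with no change in reading beyond the scatter. The two groups are quite different in what they carry: acetamido has a hydrogen-bond donor and a hydrogen-bond acceptor, and trifluoromethyl has neither, yet the readings of compound 2 and compound 4 cannot be told apart here. Nothing measured in this set explains why the two groups read alike.

Going by these compounds, whether the same position would also tolerate an amine, a carboxylic acid or a longer chain such as propionamido stays open, as does what acetamido would do elsewhere on this ring. Compound 1 and compound 3 both stand only at the limit of the assay, and neither differs from compound 4 in just one place, so what separates them from it remains unresolved.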